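Halogen Swap on the Shared Core: Cytotoxicity Outlook

The source may report more compounds than this note shows. Statements on the series, on what has been measured and on what is new or still open speak of the compounds shown alone.

Measured so far:
- compound 1 `CC1(C)OC(=O)C2(C(=O)O1)[C@@H](c1ccco1)CC(=O)C[C@H]2c1ccc(F)cc1`: > 111000 nM
- compound 2 `CC1(C)OC(=O)C2(C(=O)O1)[C@@H](c1ccco1)CC(=O)C[C@H]2c1ccc(Br)cc1`: > 111000 nM

In an ADME assay on MT2 cells (Homo sapiens) for cytotoxicity (on this read-out higher numbers stand for lower toxicity in this test and lower numbers for higher toxicity in this test), compound 1 gives > 111000 nM, which is a limit of the assay rather than a number. In this assay compound 2 gives > 111000 nM, again a limit. Going by the values given here, the only measured step, a step that the two limits leave unreadable from compound 1 to compound 2, cannot be read because of the limit of > 111000 nM in this assay, at which 2 of the 2 values shown sit. Compound 2 therefore stands only at that limit, with no number to place it.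

Compound 3 `CC1(C)OC(=O)C2(C(=O)O1)[C@@H](c1ccco1)CC(=O)C[C@H]2c1ccccc1Cl` has not yet been measured. The change is 2-chlorophenyl in place of 4-bromophenyl on a saturated ring carbon. Among the compounds with values here, no readable measured step bears on this change, since the one step known is itself unreadable. The expected step of a number no higher from compound 2 to compound 3 (the limit leaves the size open) is therefore close to none, with no direction beyond the scatter anticipated. Compound 3 is estimated at 111000 nM, between 50000 nM and 200000 nM, most likely reported again only as a limit.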

Compound 3, half-maximal cytotoxic concentration: > 111000 nM
Compound 3: only a limit was reported; the forecaster's own chance of this, stated with the estimate: 85%; the middle value lies on the limit itself.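

Going by these compounds alone, no step between compound 1, compound 2 and compound 3 can be read in this assay, because all three results are limits rather than numbers: the limit of > 111000 nM in this assay, at which 3 of the 3 values shown sit. The compounds shown leave open at what concentration each becomes toxic to the cells, and whether the three differ at all.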